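The source may hold more compounds than are shown below. What is called first, only, known or untested is meant among the compounds shown, and "the series" means these compounds.

Measured compounds in a functional assay on the whole organism (strain Swiss albino) for inhibition, with Mus musculus as the target, in the writhing test, with a stated time of 30 min, at a dose of 20 mg/kg by the oral route; a higher number here means a stronger effect of the compound at the dose given, a lower number a weaker effect:

compound 1, `Cc1c(C=O)cc(-c2ccc(S(C)(=O)=O)cc2)n1-c1cccc(F)c1`, giving 44%
compound 2, `Cc1c(C=O)cc(-c2ccc(S(C)(=O)=O)cc2)n1-c1ccccc1`, giving 32%
compound 3, `Cc1c(C#N)cc(-c2ccc(S(C)(=O)=O)cc2)n1-c1cccc(F)c1`, giving 33%

Compound 1 and compound 2 share one core; the change between them is fluoro in place of hydrogen on an aromatic carbon, and in this assay it gave a number 12 percentage points higher from compound 2 to compound 1 (beyond the scatter). Compound 3 carries a different core: the change from compound 1 to compound 3 is a cyano in place of formyl on an aromatic carbon, and it gave a number 11 percentage points lower from compound 1 to compound 3 (beyond the scatter). The difference between the core of compound 3 and the core of compound 2 is not broken down here; their two values lie within the scatter of each other.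

Compound 4, `Cc1c(C#N)cc(-c2ccc(S(C)(=O)=O)cc2)n1-c1ccc(F)c(F)c1`, has not been measured. It differs from compound 3 by fluoro in place of hydrogen on an aromatic carbon. This is the same kind of change as that from compound 2 to compound 1, but not the same: there the new fluoro stood meta to a large group, here it stands ortho to a fluoro group and para to a large group. Resting on a number 12 percentage points higher from compound 2 to compound 1 (beyond the scatter), compound 4 is expected to give a number 8 percentage points higher from compound 3 to compound 4 (within the scatter), a modest step. Compound 4 is therefore estimated at 41%, between 28% and 54%.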

Compound 4, a percentage reported as inhibition, in the whole organism at one dose (the size of the read-out at that dose, not a potency): 38%
Compound 4: middle estimate off by 3 percentage points, on the high side, and the stated range covers the measured number.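

Set on a second core, fluoro in place of hydrogen on an aromatic carbon gave a number 5 percentage points higher from compound 3 to compound 4 (within the scatter) in this assay. Beside the earlier step, the two results cannot be told apart, so the data give no sign that the core alters the size of this change: the same change on two cores in this assay, a number 12 percentage points higher (beyond the scatter) from compound 2 to compound 1 and a number 5 percentage points higher (within the scatter) from compound 3 to compound 4, 7 percentage points apart, within the scatter of two such steps This does not show that the change brings a real gain on the core of compound 3, since that step alone stays within the scatter, and two cores are too few to establish a general transfer, particularly as the fluoro of compound 4 stands ortho to a fluoro group and para to a large group, a different place from the one it holds in compound 1.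

The compounds shown leave open how chloro, methoxy or an amine would behave at that same place on the ring. They also leave open what a carboxylic acid or an amide would do where the formyl and the nitrile stand, and whether the fluoro step would hold on such a core.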